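The source may hold more compounds than are shown below. What is called first, only, known or untested is meant among the compounds shown, and "the series" means these compounds.

The study reads cytotoxicity in an ADME assay on HEL cells (Homo sapiens) for cytotoxicity, read by microscopy; a lower number here means that less compound is tolerated, a higher number that more compound is tolerated. Compound 1 `Cc1cn(CCCCCOc2ccc(Br)cc2)c(=O)[nH]c1=O` gives 100000 nM there, and compound 2 `O=c1ccn(CCCCOc2ccc(Br)cc2)c(=O)[nH]1` gives 100000 nM. Compound 3 `CCCOC(=O)c1ccc(OCCCCCn2ccc(=O)[nH]c2=O)cc1` returns only a limit in this assay, >= 100000 nM, which is the limit of >= 100000 nM in this assay, at which 1 of the 3 values shown sits. So compound 3 stands at the same concentration as the two numbers recorded for compound 1 and compound 2, though for compound 3 it is a limit rather than a measured value. Compound 4 `CC(C)c1ccc(OCCCCCn2ccc(=O)[nH]c2=O)cc1` differs from compound 3 by isopropyl in place of propoxycarbonyl on an aromatic carbon. For the measured compounds named here, no measured pair isolates such a change, so the expectation rests on the three values all sitting together. The step of a number no higher from compound 3 to compound 4 (the limit leaves the size open) is expected to be none beyond the scatter. Compound 4 is therefore estimated at 100000 nM, within 50000 nM to 100000 nM, most likely reported again as a limit.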

Compound 4, minimum cytotoxic concentration: 100000 nM
The estimate for compound 4 equals the measured number at the digits printed, and the stated range covers the measured number.
By their numbers in this assay, from the lowest: compounds 1, 2 and 4 (each within the scatter of the next).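

In this assay compound 3 returns only a limit, >= 100000 nM. With isopropyl in place of propoxycarbonyl at the same aromatic carbon, compound 4 gives a measured value, 100000 nM, the first at this position. The step of a number no higher from compound 3 to compound 4 (the limit leaves the size open) cannot be read for size, and the change shows no measurable shift: the limit of >= 100000 nM in this assay, at which 1 of the 4 values shown sits.

Going by these compounds, whether an amine or a carboxylic acid on this aromatic carbon would give a different reading in this assay remains open. So does the effect of a longer chain there.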